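Cytotoxicity limits in a pyrazoline amide series

The source may report more compounds than this note shows. Statements on the series, on what has been measured and on what is new or still open speak of the compounds shown alone.

Measured compounds:
compound 1 `O=C(c1ccncc1)N1N=C(c2cc3ccccc3o2)CC1c1ccccc1O`, > 195000 nM
compound 2 `O=C(c1ccncc1)N1N=C(c2cc3ccccc3o2)CC1c1ccccc1Cl`, > 210000 nM
compound 3 `CCn1cc(C(=O)N2N=C(c3cc4ccccc4o3)CC2c2ccc(O)cc2)c(=O)c2ccc(C)nc21`, > 148000 nM

Compound 1 `O=C(c1ccncc1)N1N=C(c2cc3ccccc3o2)CC1c1ccccc1O` is run in an ADME assay on Vero cells (Chlorocebus sabaeus) for cytotoxicity, read by MTT assay, with a stated time of 72 h; on this read-out lower numbers stand for stronger inhibition and higher numbers for weaker inhibition. Its reading, > 195000 nM, is a limit of the assay and not a number. Compound 2 `O=C(c1ccncc1)N1N=C(c2cc3ccccc3o2)CC1c1ccccc1Cl` differs by chloro in place of hydroxy on an aromatic carbon. Its reading in this assay, > 210000 nM, is likewise a limit. The step that the two limits leave unreadable from compound 1 to compound 2 therefore cannot be sized; both ends rest at a limit, as the limit of > 195000 nM in this assay, at which 1 of the 3 values shown sits, and the limit of > 210000 nM in this assay, at which 1 of the 3 values shown sits, record. Compound 3 `CCn1cc(C(=O)N2N=C(c3cc4ccccc4o3)CC2c2ccc(O)cc2)c(=O)c2ccc(C)nc21` carries another core; the difference between the two cores is not broken down here. In this assay compound 3 gives > 148000 nM, again a limit, as the limit of > 148000 nM in this assay, at which 1 of the 3 values shown sits, records.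

Compound 4 `CCn1cc(C(=O)N2N=C(c3cc4ccccc4o3)CC2c2ccc(Cl)cc2)c(=O)c2ccc(C)nc21` has not been measured. It differs from compound 3 by chloro in place of hydroxy on an aromatic carbon. This is the same kind of change as that from compound 1 to compound 2, not the same: there the place was ortho to a large group, here para to a large group. Since a step that the two limits leave unreadable from compound 1 to compound 2 is unreadable between two limits, no direction is expected, and the step that the limit leaves unreadable from compound 3 to compound 4 is estimated to stay within a limit. Compound 4 is estimated at 200000 nM, between 90000 nM and 450000 nM, most likely reported as a limit.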

Compound 4, half-maximal inhibitory concentration: > 160000 nM
Compound 4 ended at the assay's limit (the forecaster's own chance of this, stated with the estimate: 85%); the middle value is on the limit's open side.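

In this assay compound 3 gives > 148000 nM, a limit and not a number. Among the compounds shown here, compound 4 gives > 160000 nM, likewise a limit, so no step from compound 3 to compound 4 can be read. The compounds shown leave open whether chloro in place of hydroxy on an aromatic carbon changes the reading in this assay at all, since none of them has a value there that is not a limit.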